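Replacing the enamine on the piperazine with phenyl

A few compounds are considered here, and "the series" means these few. Any claim that something is new, unique, unknown or untested is made for them only; others in the source may bear on it.

Compound 3 `CN(C)/C=C/N1CCN(CC(=O)Nc2ccc(-c3nc(-c4ccccc4)c(-c4ccccc4)n3C)cc2)CC1` is the weakest of the three measured compounds in a functional assay on MCF7 cells (Homo sapiens) for cytotoxicity, read by MTT assay, with a stated time of 24 h, tested at 32 ug/mL (a higher number here means a stronger effect of the compound at the concentration tested, a lower number a weaker effect), where compound 3 gives 25.8%, compound 1 `Cn1c(-c2ccc(NC(=O)CCl)cc2)nc(-c2ccccc2)c1-c1ccccc1` gives 42.8% and compound 2 `Cc1ccc2oc(SCC(=O)Nc3ccc(-c4nc(-c5ccccc5)c(-c5ccccc5)n4C)cc3)nc2c1` gives 57.7%. Compound 4 `Cn1c(-c2ccc(NC(=O)CN3CCN(c4ccccc4)CC3)cc2)nc(-c2ccccc2)c1-c1ccccc1` differs from compound 3 by phenyl in place of 2-(dimethylamino)ethenyl on an amine nitrogen in a ring. Going by the values given here, no measured step alters this piperazine substituent, so none bears directly on it; the steps of a number 17 percentage points lower from compound 1 to compound 3 (beyond the scatter) and a number 31.9 percentage points lower from compound 2 to compound 3 (beyond the scatter) only show how far compound 3 fell when its 4-(2-(dimethylamino)ethenyl)piperazin-1-yl group entered. Any expectation for compound 4 is therefore loosely founded, and a small rise toward compound 1 is expected, a number 10.2 percentage points higher from compound 3 to compound 4 (beyond the scatter). Compound 4 is estimated at 36%, between 16% and 56%.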

Compound 4, a percentage reported as activity, at one concentration (the size of the read-out at that concentration, not a potency): 63.6%
Compound 4: middle estimate off by 27.6 percentage points, on the low side; measured number above the stated range.
By their numbers in this assay, from the lowest: compound 3; then compound 1; then compounds 2 and 4 (each within the scatter of the next).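

In this assay the substituent on this ring nitrogen proves decisive: the step is a number 37.8 percentage points higher from compound 3 to compound 4 (beyond the scatter) and so the low value of compound 3 does not hold for every 4-substituted piperazin-1-yl group. The 4-phenylpiperazin-1-yl group also gives a number 20.8 percentage points higher from compound 1 to compound 4 (beyond the scatter) and stands level with the benzoxazolyl sulfanyl group, at a number 5.9 percentage points higher from compound 2 to compound 4 (within the scatter) on the same chain carbon. Nothing available explains the size of this change. The compounds shown leave open whether a methyl or benzyl group on this nitrogen, or a 4-chlorophenyl or 4-methoxyphenyl group in place of phenyl, would keep this level.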